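A few compounds are considered here, and "the series" means these few. Any claim that something is new, unique, unknown or untested is made for them only; others in the source may bear on it.

Going by the values given here, in a functional assay on K562 cells (Homo sapiens) for antiproliferative activity, read by resazurin assay, with a stated time of 72 h (on this read-out lower numbers stand for stronger inhibition of growth and higher numbers for weaker inhibition of growth), compound 1 `CN(C)C1=NN(c2ccccc2)CN(c2ccccc2Cl)C1=O` gives 5.8 ug/mL, the only actual number so far. Compound 2 `O=C1C(N2CCCCC2)=NN(c2ccc(Cl)cc2)CN1c1ccccc1Cl` reads > 50 ug/mL, which is a limit of the assay and not a number. Compound 3 `O=C1C(N2CCCC2)=NN(c2ccccc2)CN1c1ccccc1Cl` keeps the core of compound 1 but carries pyrrolidin-1-yl in place of dimethylamino on a carbon with a double bond to nitrogen. Among the compounds with values here, no measured pair isolates this change, so only a modest weakening in this assay is expected, and that with wide uncertainty. The expected change is a 1.7-fold higher number from compound 1 to compound 3 (0.24 log units; within the scatter). The estimated value for compound 3 is 10 ug/mL, with an expected range of 3 ug/mL to 40 ug/mL.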

Compound 3, concentration for 50% growth inhibition: 5.2 ug/mL
Estimate against measurement, compound 3: 1.9-fold (0.28 log units) above, within the range that was stated.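

In this assay the swap of dimethylamino for pyrrolidin-1-yl gives a 1.1-fold lower number from compound 1 to compound 3 (0.05 log units; within the scatter) and so shows that this carbon tolerates a ring in place of the open group. Going by these compounds alone, this is the first step that isolates a single change at this position, and the larger group with its five-membered ring leaves the reading within the scatter. Nothing measured here explains why the two groups read alike. On these data alone, whether a six-membered ring such as morpholin-4-yl would read the same remains open. So does the outcome for a longer chain such as diethylamino.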